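Notes on the aryl group: pyridin-3-yl to 2-methylphenyl

The source may report more compounds than this note shows. Statements on the series, on what has been measured and on what is new or still open speak of the compounds shown alone.

Measured in an assay on CHO cells for displacement of a labelled ligand from adenosine receptor A1 (Homo sapiens), read by scintillation counting, with a stated time of 3 h; a higher number here means a weaker inhibitor, a lower number a stronger inhibitor:
compound 1 `Cn1c(-c2ccc(O)cc2)nc2c(NC3CCCC3)ncnc21` gives 17 nM
compound 2 `Cn1c(-c2ccccc2Cl)nc2c(NC3CCCC3)ncnc21` gives 37 nM
compound 3 `Cn1c(-c2cccnc2)nc2c(NC3CCCC3)ncnc21` gives 242 nM

Compound 3 stands at the highest number of the three. Its nearest neighbour is compound 2, with a 6.5-fold higher number from compound 2 to compound 3 (0.82 log units; beyond the scatter); the furthest is compound 1, with a 14-fold higher number from compound 1 to compound 3 (1.15 log units; beyond the scatter). Both of those steps swap one six-membered aromatic ring for another on the same carbon of the shared core, and both go beyond the scatter.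

Compound 4 `Cc1ccccc1-c1nc2c(NC3CCCC3)ncnc2n1C` differs from compound 3 in that one place only: 2-methylphenyl in place of pyridin-3-yl on an aromatic carbon. The step that bears most directly on it is a 6.5-fold higher number from compound 2 to compound 3 (0.82 log units; beyond the scatter), since 2-chlorophenyl and 2-methylphenyl are both carbon-only rings of the same size, each named with a 2-substituent, while pyridin-3-yl is the ring with the one nitrogen. Reversing the ring type is therefore expected to reverse most of that step, giving a modest move to a lower number in this assay, in the direction of compound 2. The expected step is a 5.4-fold lower number from compound 3 to compound 4 (0.73 log units; beyond the scatter).

Compound 4 is estimated at 45 nM, within 15 nM to 130 nM.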

Compound 4, inhibition constant: 55 nM
Estimate against measurement, compound 4: 1.2-fold (0.09 log units) below, and the stated range covers the measured number.
By their numbers in this assay, from the lowest: compound 1; then compounds 2 and 4 (each within the scatter of the next); then compound 3.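

With a 4.4-fold lower number from compound 3 to compound 4 (0.64 log units; beyond the scatter), 2-methylphenyl joins 4-hydroxyphenyl and 2-chlorophenyl as a carbon-only ring that gives a lower number than pyridin-3-yl in this assay, and none of the four compounds goes against this. Methyl and chloro on the aryl ring are not told apart here, with a 1.5-fold higher number from compound 2 to compound 4 (0.17 log units; within the scatter), so compounds 2 and 4 read as one level. The 4-hydroxyphenyl ring stays distinct from 2-methylphenyl as well as from 2-chlorophenyl, with a 3.2-fold higher number from compound 1 to compound 4 (0.51 log units; beyond the scatter), so a carbon-only ring alone does not set the number at this position.

Still open, as far as these compounds go, is whether the low number of compound 1 goes with the hydroxy group itself or with its place on the ring, which a 2-hydroxyphenyl or a 4-methylphenyl ring would help to separate. Also open, from the compounds shown here alone, is how an unsubstituted phenyl ring, or a saturated ring such as cyclohexyl, would compare with these aryl groups on the same carbon of the shared core.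

Nothing at hand gives a reason for any of these steps, so they stand as observations only.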